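The source may hold more compounds than are shown below. What is called first, only, known or untested is meant among the compounds shown, and "the series" means these compounds.

Of the compounds shown here, two have so far been tested in an assay on isolated protein for inhibition of histone acetyltransferase KAT2B (Homo sapiens), read by fluorescence, with a stated time of 15 min; a higher number here means a weaker inhibitor, a lower number a stronger inhibitor. Compound 1 `CCn1c(=O)cc(Cl)[s+]1[O-]` reaches only the limit of the assay, giving > 10000 nM. Compound 2 `CCCCCCCCCCCCSc1cc(=O)n(C(C)(C)C)[s+]1[O-]` likewise reaches only the limit, giving > 10000 nM in this assay. Going by the values given here, both values sit at the limit of > 10000 nM in this assay, at which 2 of the 2 values shown sit, so compound 2 stands at the limit together with the only other value shown, and no measured step exists for comparison. Compound 3 `CCCCCCCCCCCCSc1cc(=O)n(CCC(=O)OC)[s+]1[O-]` differs from compound 2 by 2-(methoxycarbonyl)ethyl in place of tert-butyl on an aromatic nitrogen. No shift beyond the scatter is expected in this assay. Compound 3 is therefore estimated at 20000 nM, in a range of 5000 nM to 80000 nM. The expected step that the limit leaves unreadable from compound 2 to compound 3 is accordingly small.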

Compound 3, half-maximal inhibitory concentration: > 10000 nM
Compound 3: no number, only a limit (the forecaster's own chance of this, stated with the estimate: 85%); the middle value is on the limit's open side.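

Going by these compounds alone, compound 2 and compound 3 both give only a limit of the assay, and no step between them can be read. The compounds shown leave open whether in this assay any change on the shared core gives a measurable value.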